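Plasma stability after exchanging the amide-side group

The source may report more compounds than this note shows. Statements on the series, on what has been measured and on what is new or still open speak of the compounds shown alone.

Measured compounds:
compound 1, `CCCc1nc(C(C)(C)O)c(C(=O)NCCCCCC[N+](=O)[O-])n1Cc1ccc(-c2ccccc2C2=NNNN2)cc1`: 101%
compound 2, `CCCc1nc(C(C)(C)O)c(C(=O)NCCCCCCC(=O)O)n1Cc1ccc(-c2ccccc2C2=NNNN2)cc1`: 97.5%

In an ADME assay on a cell-free system (plasma, Rattus norvegicus, strain Sprague-Dawley) for metabolic stability, with a stated time of 30 min, tested at 50 mg/mL (a higher number here means that more of the compound is left, a lower number that less of the compound is left), compound 2 gives 97.5%, the lower of the two numbers, with compound 1 nearest at 101%; the step of a number 3.5 percentage points lower from compound 1 to compound 2 (within the scatter) is within the scatter, so the two stand together.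

Compound 3, `CCCc1nc(C(C)(C)O)c(C(=O)OCc2c[nH]c(=O)[nH]c2=O)n1Cc1ccc(-c2ccccc2C2=NNNN2)cc1`, is not yet measured. It differs from compound 2 by a group of 10 heavy atoms (5 carbon, 2 nitrogen, 3 oxygen; one six-membered aromatic ring with 2 hetero atoms) in place of a group of 10 heavy atoms (7 carbon, 1 nitrogen, 2 oxygen; no ring), on a carbonyl carbon. Going by the values given here, the one measured step, from compound 1 to compound 2, changes only the terminal group at the far end of the chain, six bonds from the amide-type nitrogen, whereas the step to compound 3 replaces that whole chain together with its nitrogen by a ring-bearing group on the carbonyl carbon. That measured step therefore bears only loosely on this one, and its size was within the scatter. Among the compounds with values here, with no closer precedent, compound 3 is expected to stay near compound 2, with a wide range, the step of a number 12.5 percentage points lower from compound 2 to compound 3 (beyond the scatter) being an estimate. Compound 3 is thus estimated at 85%, between 45% and 102%.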

Compound 3, percent of the compound remaining: 96.3%
The estimate for compound 3 lay 11.3 percentage points below the measured number; the measured number falls inside the stated range.
By their numbers in this assay, from the lowest: compounds 3, 2 and 1 (each within the scatter of the next).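

In this assay the exchange at this place gives a number 1.2 percentage points lower from compound 2 to compound 3 (within the scatter), and the same group set against the nitro-ended chain gives a number 4.7 percentage points lower from compound 1 to compound 3 (within the scatter). The earlier pair had shown only that the far end of the chain could change without separating the numbers; these steps show the same for the whole group on the carbonyl carbon whose other neighbour is an aromatic carbon, where the (6-carboxyhexyl)amino group, with its nitrogen, gives way to a group carrying one six-membered aromatic ring with 2 hetero atoms. Nothing measured here offers an explanation for why the three compounds stand together.

With no step among these compounds beyond the scatter, nothing yet shows which kind of group on this carbonyl carbon, if any, would move the percentage of compound remaining. Going by these compounds, whether a short alkyl amine, a simple methyl ester or a longer chain ending in a carboxylic acid at the same place would stand with these three remains open.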